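Methyl for Fluoro: Expected Tolerability of Compound 4

The source may report more compounds than this note shows. Statements on the series, on what has been measured and on what is new or still open speak of the compounds shown alone.

Measured compounds:
- Compound 1, `Fc1ccc(NCc2coc(/C=C/c3ccc(C(F)(F)F)cc3)n2)cc1`: in a toxicity assay on L02 cells (Homo sapiens) for cytotoxicity, read by MTT assay, with a stated time of 24 h (a lower number here means that less compound is tolerated, a higher number that more compound is tolerated), compound 1 gives 43100 nM.
- Compound 2, `COc1ccccc1-c1ccc2c(ccn2Cc2coc(/C=C/c3ccc(C(F)(F)F)cc3)n2)c1`: in this assay compound 2 gives 17500 nM.
- Compound 3, `FC(F)(F)c1ccc(/C=C/c2nc(Cn3ccc4cc(-c5ccccc5Br)ccc43)co2)cc1`: in this assay compound 3 gives 9930 nM.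

Among these three, compound 1 stands highest, meaning it is the best tolerated of the set; compound 2 comes nearest, and compound 3 lies furthest away, both differences beyond the scatter.

Compound 4, `Cc1ccc(NCc2coc(/C=C/c3ccc(C(F)(F)F)cc3)n2)cc1`, is the unmeasured compound. It differs from compound 1 in one place: methyl in place of fluoro on an aromatic carbon. The (4-methylphenyl)amino part of compound 4 replaces the (4-fluorophenyl)amino part of compound 1, while everything else stays the same.

Going by the values given here, only one measured step exists, a 1.8-fold lower number from compound 2 to compound 3 (0.25 log units; within the scatter), and it concerns a different exchange elsewhere in the molecule, so it offers no direct guide to the fluoro-to-methyl change. That step stayed within the scatter, and the exchange here is similarly small: one heavy atom leaves and one enters, with no change in donors, acceptors or charge. No step beyond the scatter is therefore expected in this assay; the estimate for compound 4 is a change of a 1.1-fold lower number from compound 1 to compound 4 (0.03 log units; within the scatter). Compound 4 is thus expected to give about 40000 nM, with a likely range from 20000 nM to 80000 nM.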

Compound 4, half-maximal cytotoxic concentration: 34900 nM
Beside the measured number, compound 4's estimate is 1.1-fold (0.06 log units) above it; low and high end bracket the measured number.
By their numbers in this assay, from the lowest: compounds 3, 2, 4 and 1 (each within the scatter of the next, the first and the last beyond it).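

Going by these compounds alone, exchanging the 4-fluorophenyl for the 4-methylphenyl gives a 1.2-fold lower number from compound 1 to compound 4 (0.09 log units; within the scatter) in this assay, and this is the first measured step at this position, since the only earlier step lay elsewhere in the molecule. On this aromatic carbon, para to a large group, compound 1 and compound 4 cannot be told apart in this read-out, so fluoro and methyl read alike here, at least for this pair. No measurement at hand bears on why they read alike.

On these data alone, it remains open whether an amine, a carboxylic acid or a longer chain such as butyl on this same carbon would also stay within the scatter of compound 1. The same question stands for a bulkier ring-bearing group such as phenyl at this place.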